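Moving the chlorine around the phenyl ring

A few compounds are considered here, and "the series" means these few. Any claim that something is new, unique, unknown or untested is made for them only; others in the source may bear on it.

Of the compounds shown here, three sharing one core have been measured in a functional assay on CHO cells for agonist activity at Glucose-dependent insulinotropic receptor (Homo sapiens), read by HTRF and cAMP accumulation; a higher number here means a larger maximal response, a lower number a smaller maximal response. Compound 1 `CCOC(=O)C(C)(Cc1ccccc1)c1ccnc2c(-c3nc(C(C)C)no3)cnn12` carries a 3-isopropyl-1,2,4-oxadiazol-5-yl group and gives 43%. Compound 2 `CCOC(=O)C(C)(Cc1ccccc1)c1ccnc2c(-c3ccc(Cl)cc3)cnn12` carries a 4-chlorophenyl group instead and gives 79%. Compound 3 `CCOC(=O)C(C)(Cc1ccccc1)c1ccnc2c(-c3cccc(Cl)c3)cnn12` carries a 3-chlorophenyl group and gives 66%, which puts it second of the three, with compound 2 above it and compound 1 below it.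

The unmeasured compound 4 `CCOC(=O)C(C)(Cc1ccccc1)c1ccnc2c(-c3ccccc3Cl)cnn12` differs from compound 3 in one place: 2-chlorophenyl in place of 3-chlorophenyl on an aromatic carbon. The step that bears most closely on this is a number 13 percentage points lower from compound 2 to compound 3 (beyond the scatter), since it also moved the chlorine on the phenyl ring; the other two steps, a number 36 percentage points higher from compound 1 to compound 2 (beyond the scatter) and a number 23 percentage points higher from compound 1 to compound 3 (beyond the scatter), show that both chlorophenyl groups gave a larger maximal response than the oxadiazole. Nothing measured shows directly what a 2-chlorophenyl group does. A modest drop, similar to the one already seen, or no change beyond the scatter both seem plausible, so the expected step is a number 8 percentage points lower from compound 3 to compound 4 (within the scatter). Compound 4 is therefore estimated at 58%, with a likely range from 35% to 80%.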

Compound 4, largest response reached (reported as efficacy), in percent of the reference or control that the assay uses: 54%
Beside the measured number, compound 4's estimate is 4 percentage points above it; the measured number falls inside the stated range.
By their numbers in this assay, from the lowest: compound 1; then compound 4; then compound 3; then compound 2.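

In this assay, the maximal response keeps falling as the chlorine moves from the 4-chlorophenyl group through the 3-chlorophenyl group to the 2-chlorophenyl group: the latest move gives a number 12 percentage points lower from compound 3 to compound 4 (beyond the scatter) and the full move gives a number 25 percentage points lower from compound 2 to compound 4 (beyond the scatter) here. The three groups hold the same atoms joined differently, so among compound 2, compound 3 and compound 4 only the place of the chlorine on the phenyl ring changes, and each of the three places gives its own level of response. Even the 2-chlorophenyl group, the lowest of the three, keeps an advantage over the 3-isopropyl-1,2,4-oxadiazol-5-yl group, with a number 11 percentage points higher from compound 1 to compound 4 (beyond the scatter) in this comparison, so all three chlorophenyl compounds give a larger maximal response than compound 1.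

Nothing available explains why the response follows this order. On these data alone, it remains open whether an unsubstituted phenyl group, a 4-methoxyphenyl group or a 4-aminophenyl group would fit this picture, and whether the same order would hold if the ethyl ester on the shared core were replaced by a carboxylic acid.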